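A few compounds are considered here, and "the series" means these few. Any claim that something is new, unique, unknown or untested is made for them only; others in the source may bear on it.

Measured so far:
- Compound 1, `CC(=O)N1CCC(n2cc(-c3cnc(N)c4oc(-c5cccc6ccccc56)cc34)cn2)CC1`: in an ADME assay on microsomes from liver (Mus musculus) for metabolic stability (a lower number here means that the liver removes a smaller share, a higher number that the liver removes a larger share of the compound in one pass), compound 1 gives 0.77
- Compound 2, `CC(=O)N1CCC(n2cc(-c3cnc(N)c4oc(-c5cccc6nnsc56)cc34)cn2)CC1`: compound 2 gives 0.7
- Compound 3, `CC(=O)N1CCC(n2cc(-c3cnc(N)c4oc(-c5cccc6cnsc56)cc34)cn2)CC1`: compound 3 gives 0.84

All three share one core and differ only in the two-ring group attached to it. Among the compounds with values here, compound 3 carries the largest number of the three, but the step a number 0.070 higher from compound 1 to compound 3 (within the scatter) is within the scatter, so compound 3 and compound 1 cannot be told apart on this evidence; only the step a number 0.14 higher from compound 2 to compound 3 (beyond the scatter) is beyond it, and even that is modest.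

Compound 4, `CC(=O)N1CCC(n2cc(-c3cnc(N)c4oc(-c5cn(C)c6cnccc56)cc34)cn2)CC1`, is the next member of this series. Compared with compound 3 the change is a group of 10 heavy atoms (8 carbon, 2 nitrogen; one five-membered aromatic ring with 1 hetero atom, one six-membered aromatic ring with 1 hetero atom) in place of a group of 9 heavy atoms (7 carbon, 1 nitrogen, 1 sulfur; one five-membered aromatic ring with 2 hetero atoms, one six-membered aromatic ring of carbon only), on an aromatic carbon

Every measured step bears on this one, since each also swaps the two-ring group on the same aromatic carbon: a number 0.070 lower from compound 1 to compound 2 (within the scatter), a number 0.070 higher from compound 1 to compound 3 (within the scatter) and a number 0.14 higher from compound 2 to compound 3 (beyond the scatter). None of these exchanges moved the number by much, so a swap to yet another two-ring group is expected to give no step beyond the scatter in this assay, in either direction. The expected step from compound 3 is a number 0.080 lower from compound 3 to compound 4 (within the scatter). Compound 4 is therefore estimated at 0.76, with a range from 0.6 to 0.9.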

Compound 4, hepatic extraction ratio: 0.91
The estimate for compound 4 lay 0.15 below the measured number; the measured number lies above the stated range.
By their numbers in this assay, from the lowest: compounds 2, 1, 3 and 4 (each within the scatter of the next, the first and the last beyond it).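

At this aromatic carbon next to the ring oxygen, the group of compound 4, which holds carbon and nitrogen but no sulfur and has a hetero atom in each of its two rings, stands apart from two earlier groups in this assay: a number 0.21 higher from compound 2 to compound 4 (beyond the scatter) and a number 0.14 higher from compound 1 to compound 4 (beyond the scatter). Within the data shown here, this is the first exchange of two-ring groups to move the number beyond the scatter starting from compound 1, though the shift is modest, and the series now spans a wider range, with the two groups of compound 2 and compound 4 furthest apart. Against its direct neighbour the change does not register, at a number 0.070 higher from compound 3 to compound 4 (within the scatter), and no measurement is at hand that would explain any of these differences between groups.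

The group of compound 4 differs from the others in several atoms at once, so these compounds do not separate the loss of sulfur from the gain of a nitrogen in the six-membered ring. They also leave open how a single-ring group such as phenyl, or a two-ring group carrying an amine or a carboxylic acid, would behave at this position.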